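Isopropyl in place of pyrazolyl on the benzyl ring

This account rests on a few compounds, and the source may have more. Where it says the series, first, only, none or still open, it means among the compounds named here.

Measured compounds:
compound 1 `COc1cccc(NC(=O)c2nnn(Cc3ccc(-n4cccn4)cc3)c2N)c1`: 2.4
compound 2 `COc1cccc(NC(=O)c2nnn(CC3CCN(C(=O)OC(C)(C)C)CC3)c2N)c1`: 2.9

In a physicochemical assay for lipophilicity, read by HPLC, measured as chromatographic lipophilicity, at pH 7.4 (on this read-out higher numbers stand for higher lipophilicity and lower numbers for lower lipophilicity), compound 1 gives 2.4, the lowest of the two numbers; compound 2 gives 2.9, a gap beyond the scatter. Compound 3 `COc1cccc(NC(=O)c2nnn(Cc3ccc(C(C)C)cc3)c2N)c1` has not yet been measured. It differs from compound 1 by isopropyl in place of 1H-pyrazol-1-yl on an aromatic carbon. The change removes a five-membered aromatic ring with two hydrogen-bond acceptors and brings in a group of three carbon atoms with none. Among the measured compounds shown here, no measured pair shows this change. The step of a number 1.00 log units higher from compound 1 to compound 3 (beyond the scatter) is expected to be a clear rise, beyond the scatter. Compound 3 is estimated at 3.4, between 3 and 3.9.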

Compound 3, distribution coefficient: 3.4
For compound 3 middle estimate and measured number coincide at the digits printed; the range from low to high includes it.
By their numbers in this assay, from the lowest: compound 1; then compound 2; then compound 3.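

At this position, on an aromatic carbon para to a large group, this assay responds to the substituent: isopropyl in place of 1H-pyrazol-1-yl gives a number 1.00 log units higher from compound 1 to compound 3 (beyond the scatter). The earlier compounds shown here offered no step that isolated this position. No measurement shown says what lies behind the step.

The compounds shown leave open whether the rise follows the departure of the five-membered aromatic ring or the arrival of isopropyl, which a phenyl ring or a tert-butyl group here could help separate. From the compounds shown here alone, how the number would move with an amine or a carboxylic acid on this carbon also remains open.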